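Amino in place of hydrogen on compound 3

The compounds below may be only part of what the source reports. "The series", "measured", "known", "first", "only" and "open" are said of these compounds alone.

- Compound 1 `COC(=O)c1ccc([N+](=O)[O-])o1`: 32000 nM
- Compound 2 `O=C(NNC(=O)c1ccc([N+](=O)[O-])o1)c1ccc([N+](=O)[O-])o1`: 32000 nM
- Compound 3 `O=C(NNC(=O)c1ccc([N+](=O)[O-])o1)c1ccc2ccccc2c1`: 32000 nM

These three compounds were all tested in a functional assay (Mus musculus) for cytotoxicity; on this read-out higher numbers stand for lower toxicity in this test and lower numbers for higher toxicity in this test. Compound 3 stands level with compound 1 and compound 2 at the digits shown, and nothing separates the three beyond the scatter.

The next compound, compound 4 `Nc1ccc2cc(C(=O)NNC(=O)c3ccc([N+](=O)[O-])o3)ccc2c1`, has not yet been measured. It departs from compound 3 in one place: amino in place of hydrogen on an aromatic carbon. This is amino in place of hydrogen on an aromatic carbon of a six-membered aromatic ring of carbon only, part of a fused or bridged system of two rings.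

Within the data shown here, no two measured compounds differ in one place only, so the data offer no direct precedent for this change. They do show that structurally different compounds can share a reading: compound 2 and compound 3 both give 32000 nM in this assay. Only a small shift is therefore expected, leaning towards lower numbers, which would mean somewhat higher toxicity in this test. The expected change is a 1.2-fold lower number from compound 3 to compound 4 (0.09 log units; within the scatter), and it is not expected to go beyond the scatter. For compound 4 the estimated value is 26000 nM, with an expected range from 10000 nM to 40000 nM.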

Compound 4, half-maximal cytotoxic concentration: 32000 nM
For compound 4 the middle estimate is 1.2-fold (0.09 log units) below the measured one; low and high end bracket the measured number.
By their numbers in this assay, from the lowest: compounds 1, 2, 3 and 4 (each within the scatter of the next).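

Among these compounds, replacing hydrogen with amino on an aromatic carbon of a six-membered aromatic ring of carbon only, part of a fused or bridged system of two rings, gives the first direct reading of any single change in this assay: no change at the digits printed from compound 3 to compound 4 (within the scatter). At this position, meta to a fused ring and para to a fused ring, the added amino group therefore leaves this read-out undisturbed, with compound 4 at 32000 nM, so the site accepts this one nitrogen-bearing group without a step beyond the scatter. Nothing in the available data offers an explanation for this outcome.

The compounds shown leave open whether a different group on the same aromatic carbon, such as a hydroxyl, a methoxy or a carboxylic acid, or the same amino group on another carbon of that ring, would read differently in this assay. With a single step to go on, they also leave open whether amino in place of hydrogen would give the same reading on a core other than that of compound 3.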